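The source may hold more compounds than are shown below. What is called first, only, known or untested is meant among the compounds shown, and "the series" means these compounds.

Working notes on the series. Compound 1 `Cc1cc(C)c(-c2nc(CN3CCC(C(=O)NCCCN4C[C@H](C)C[C@H](C)C4)CC3)c(C)o2)c(C)c1` has in a physicochemical assay for permeability, using PAMPA (a higher number here means that the compound crosses the layer faster, a lower number that the compound crosses the layer more slowly), only the entry "not determined" (no result reported); for it there is no single number to stand on. For the measured compounds named here, the one measured member is compound 2 `Cc1ccccc1-c1nc(CN2CCC(C(=O)NCCCN3CCC(C(C)C)CC3)CC2)c(C)o1`, and in this assay compound 2 gives 396 10^-6 cm/s. Going by the values given here, no pair of measured compounds differing in one place is available, so no step size has been observed.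

The next member is compound 3 `CCc1ccccc1-c1nc(CN2CCC(C(=O)NCCCN3C[C@H](C)C[C@H](C)C3)CC2)c(C)o1`, which differs from compound 1 by 2-ethylphenyl in place of 2,4,6-trimethylphenyl on an aromatic carbon. Among the compounds with values here, with no number for compound 1, no computed step can be given for this change; the expectation for this assay is no shift beyond the usual scatter, in either direction, taking the measured value of compound 2 as the only anchor. Compound 3 shares most of its skeleton with compound 2, whose result in this assay is 396 10^-6 cm/s.

Compound 3 is expected to give 350 10^-6 cm/s in this assay, within a range from 150 10^-6 cm/s to 700 10^-6 cm/s.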

Compound 3, apparent permeability: 106 10^-6 cm/s
Compound 3: middle estimate off by 3.3-fold (0.52 log units), on the high side; the measured number lies below the stated range.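

For the compounds shown here, compound 1 has no single number in this assay, so no step to compound 3 can be read. The compounds shown leave open how 2-ethylphenyl in place of 2,4,6-trimethylphenyl shifts this read-out. No supporting evidence bears on the result for compound 3.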